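This account rests on a few compounds, and the source may have more. Where it says the series, first, only, none or still open, it means among the compounds named here.

Measured in a functional assay on A549 cells (Homo sapiens) for inhibition, read by MTT assay, with a stated time of 72 h; a lower number here means a stronger inhibitor, a higher number a weaker inhibitor:
- compound 1 `CNC(=O)CCCCCCCn1nc(-c2cnc3[nH]ccc3c2)c2c(N)ncnc21`: 51000 nM
- compound 2 `Nc1ncnc2c1c(-c1cnc3[nH]ccc3c1)nn2CCCCCCCCCC(=O)NO`: 6550 nM
- compound 3 `Nc1ncnc2c1c(-c1cnc3[nH]ccc3c1)nn2CCCCCCC(=O)NO`: 50000 nM

Compound 3 sits level with compound 1, as a 1.0-fold lower number from compound 1 to compound 3 (0.01 log units; within the scatter) shows, and well clear of compound 2, as a 7.6-fold higher number from compound 2 to compound 3 (0.88 log units; beyond the scatter) shows. The next structure is compound 4 `Nc1ncnc2c1c(-c1cnc3[nH]ccc3c1)nn2CCCC(=O)NO`, and the change leading to it is hydroxycarbamoyl in place of 3-(hydroxycarbamoyl)propyl on a saturated chain carbon, three bonds along the chain from an aromatic nitrogen.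

Among the compounds with values here, the closest precedent is a 7.6-fold higher number from compound 2 to compound 3 (0.88 log units; beyond the scatter). That is the same exchange, hydroxycarbamoyl in place of 3-(hydroxycarbamoyl)propyl, made six bonds along the chain from an aromatic nitrogen rather than three. It was a modest step, beyond the scatter, toward a higher number. Within the data shown here, it is the only such step available, so the direction is better supported than the size. Compound 1, which carries methylcarbamoyl instead of hydroxycarbamoyl, already gives 51000 nM, and this argues for caution about a further large rise in this assay.

The expected change is a smaller move the same way, a 1.5-fold higher number from compound 3 to compound 4 (0.18 log units; within the scatter). Compound 4 is estimated at 75000 nM, with an expected range of 30000 nM to 200000 nM.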

Compound 4, half-maximal inhibitory concentration: > 150000 nM
Compound 4: a limit, no number (the forecaster's own chance of this, stated with the estimate: 35%); at least 2.0-fold (0.30 log units) between middle value and limit.
By their numbers in this assay, from the lowest: compound 2; then compounds 3 and 1 (each within the scatter of the next). At a limit, above all of these: compound 4.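

In this assay compound 4 reads as a limit, not a number: the limit of > 150000 nM in this assay, at which 1 of the 4 values shown sits.

The exchange of 3-(hydroxycarbamoyl)propyl for hydroxycarbamoyl, made three bonds along the chain from an aromatic nitrogen, keeps the direction seen six bonds along, with an at least 3.0-fold higher number from compound 3 to compound 4 (0.47 log units; beyond the scatter), and across the three hydroxycarbamoyl compounds the number rises as the chain shortens, with an at least 22-fold higher number from compound 2 to compound 4 (1.35 log units; beyond the scatter). Compounds 1 and 3 had stood level, but the shortest chain now separates from the methylcarbamoyl compound too, with an at least 2.9-fold higher number from compound 1 to compound 4 (0.46 log units; beyond the scatter), so hydroxycarbamoyl on this chain brings no gain over it.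

As far as these compounds go, whether a longer chain than that of compound 2 lowers the number further stays open, as does whether a carboxylic acid at the chain end can stand in for hydroxycarbamoyl. From the compounds shown here alone, how far compound 4 lies past its limit also stays open.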